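Methoxy on the propyl terminus of compound 1

The compounds below may be only part of what the source reports. "The series", "measured", "known", "first", "only" and "open" are said of these compounds alone.

Three analogues sharing one core have numbers in an assay on HEK293 cells for displacement of a labelled ligand from corticotropin-releasing factor receptor 1 (Homo sapiens); a higher number here means a weaker inhibitor, a lower number a stronger inhibitor. Compound 1 `CCCN(CC)c1cc(C)nc2c(-c3ccc(Cl)cc3Cl)nn(C)c12` gives 4.1 nM. Compound 2 `CCCCN(c1cc(C)nc2c(-c3ccc(Cl)cc3Cl)nn(C)c12)C(CC)CC`, which carries a butyl and a branched pentyl on the ring nitrogen, gives 7 nM. Compound 3 `CCCCN(CCCC)c1cc(C)nc2c(-c3ccc(C)cc3Cl)nn(C)c12`, with two butyl groups and a methyl in place of one chlorine on the pendant aryl ring, gives 2.8 nM. Compound 1 sits between the other two: the gap to compound 3 and the gap to compound 2 both lie within the usual scatter, so the three values cannot be ordered with confidence. Variation of the two chains on the ring nitrogen, as far as these three show, leaves the value roughly where it is.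

Compound 4 `CCN(CCCOC)c1cc(C)nc2c(-c3ccc(Cl)cc3Cl)nn(C)c12` has not been measured. It differs from compound 1 by methoxy in place of hydrogen on a saturated chain carbon, three bonds along the chain from a nitrogen on an aromatic ring. Going by the values given here, no measured pair here shows this particular change, so any expectation rests on the small spread among compounds 1, 2 and 3. The step from compound 1 to compound 4 is expected to be small, at most a slight rise, and not clearly beyond the scatter: a 1.5-fold higher number from compound 1 to compound 4 (0.17 log units; within the scatter). Compound 4 is therefore expected to give about 6 nM in this assay, with a likely range from 2.5 nM to 15 nM.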

Compound 4, inhibition constant: 12.5 nM
Compound 4: middle estimate off by 2.1-fold (0.32 log units), on the low side; measured number inside the range.
By their numbers in this assay, from the lowest: compounds 3, 1, 2 and 4 (each within the scatter of the next, the first and the last beyond it).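

In this assay, going by these compounds alone, methoxy in place of hydrogen on a saturated chain carbon, three bonds along the chain from a nitrogen on an aromatic ring, gives a 3.0-fold higher number from compound 1 to compound 4 (0.48 log units; beyond the scatter); this is the only single-place step so far, and it shows that the end of the propyl chain is not indifferent to substitution, which the three earlier compounds, each differing from the others in more than one place, could not show. The change from propyl to 3-methoxypropyl is a modest loss rather than a collapse, since compound 4 still gives 12.5 nM. Nothing shown here bears on the reason for this rise.

Still open, as far as these compounds go, is whether the rise follows from the oxygen or simply from the longer chain, a question that a straight pentyl chain on the core of compound 1 would help to settle. Also open, from the compounds shown here alone, is how a hydroxyl, an amine or a carboxylic acid at the same chain end would compare, and whether 2-methoxyethyl, with its shorter chain, would behave like 3-methoxypropyl.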